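Removing a Chloro Group: Effect on Vero Cell Cytotoxicity

The source may report more compounds than this note shows. Statements on the series, on what has been measured and on what is new or still open speak of the compounds shown alone.

Of the compounds shown here, three sharing one core have been measured in an ADME assay on Vero cells (Chlorocebus sabaeus) for cytotoxicity, with a stated time of 72 h, tested at 10 ug/mL; a higher number here means a stronger effect of the compound at the concentration tested, a lower number a weaker effect. Compound 1 `Cc1cccc(N2CCn3c2n[nH]c(=O)c3=O)c1C` gives 18%. Compound 2 `N=c1c(=O)[nH]nc2n1CCN2c1ccc(Cl)cc1` gives 0%. Compound 3 `Cc1ccc(N2CCn3c2n[nH]c(=O)c3=O)cc1` gives 0%. On these numbers compound 2 stands level with compound 3 at the digits shown, the two together at the low end, and its gap to compound 1 is the widest, a step beyond the usual scatter.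

Compound 4 `N=c1c(=O)[nH]nc2n1CCN2c1ccccc1` has not yet been measured in this assay. It differs from compound 2 in one place: hydrogen in place of chloro on an aromatic carbon. A chloro leaves and a hydrogen enters on an aromatic carbon of a six-membered aromatic ring of carbon only. Among the compounds with values here, no pair of measured compounds differs in only one place, so there is no measured step of this kind to lean on. Because compound 2 gives 0% and compound 3 gives 0%, both at the low end of the measured numbers, the expectation for this small change is no step beyond the scatter. The expected step is a number 2 percentage points higher from compound 2 to compound 4 (within the scatter). Compound 4 is expected to give about 2%, within a range from -8% to 14%.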

Compound 4, a percentage reported as inhibition, at one concentration (the size of the read-out at that concentration, not a potency): 26%
Estimate against measurement, compound 4: 24 percentage points below; measured number outside the range, above it.
By their numbers in this assay, from the lowest: compounds 2 and 3 (each within the scatter of the next); then compounds 1 and 4 (each within the scatter of the next).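

Taking the chloro off the aromatic ring is not a neutral change in this assay: with hydrogen in its place, para to a large group, the read-out shows a number 26 percentage points higher from compound 2 to compound 4 (beyond the scatter). Within the data shown here, this links the chloro position directly to the size of the effect at the tested concentration, something the earlier compounds could not do, as no two of them differ in only one place. No measurement at hand explains the step.

Still open, as far as these compounds go, is whether a different group at this place, such as fluoro, methoxy or an amine, would stay close to chloro or to hydrogen. Also open, from the compounds shown here alone, is whether the same swap of chloro for hydrogen would give a step of similar size on the core of compound 1.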